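Swapping an ester for a nitrile on a shared core

This account rests on a few compounds, and the source may have more. Where it says the series, first, only, none or still open, it means among the compounds named here.

Compound 1 (`N#Cc1c(N)sc(C(=O)Nc2ccccc2)c1-c1ccccc1`): 9620 nM
Compound 2 (`CCOC(=O)c1c(NC(=O)CC#N)sc(C(=O)Nc2ccccc2)c1-c1ccccc1`): 490 nM

In a functional assay on NCI-H460 cells (Homo sapiens) for inhibition, read by MTT assay (on this read-out higher numbers stand for weaker inhibition and lower numbers for stronger inhibition), compound 2 gives the lower of the two numbers, 490 nM, while compound 1 gives 9620 nM. That gap lies well beyond the scatter, but the two compounds differ in more than one place, so it cannot be assigned to any single group.

The next compound is compound 3 (`N#CCC(=O)Nc1sc(C(=O)Nc2ccccc2)c(-c2ccccc2)c1C#N`), which follows from compound 2 through one change: cyano in place of ethoxycarbonyl on an aromatic carbon. In short, cyano takes the place of ethoxycarbonyl on an aromatic carbon, and the rest of the molecule stays the same.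

For the measured compounds named here, no measured pair shows this change alone, so any forecast in this assay is uncertain. Compound 1, at 9620 nM, also carries a cyano but has no ((cyanomethyl)carbonyl)amino group, so it offers only a loose hint. A modest move towards a higher number is expected, possibly no larger than the scatter. The expected change is a 1.8-fold higher number from compound 2 to compound 3 (0.26 log units; within the scatter). For compound 3 the estimated value is 900 nM, with an expected range of 220 nM to 3600 nM.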

Compound 3, half-maximal inhibitory concentration: 8060 nM
The estimate for compound 3 lay 9.0-fold (0.95 log units) below the measured number, outside the stated range (above it).
By their numbers in this assay, from the lowest: compound 2; then compounds 3 and 1 (each within the scatter of the next).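

For the compounds shown here, this is the first pair in which only the group on this aromatic carbon differs, and in this assay the position proves sensitive: cyano in place of ethoxycarbonyl, with the rest of the molecule unchanged, gives a large step (a 16-fold higher number from compound 2 to compound 3 (1.22 log units; beyond the scatter)). The second pair, which keeps cyano on that carbon and differs only in having (cyanomethyl)carbonyl in place of hydrogen on the nitrogen, gives a step within the scatter (a 1.2-fold lower number from compound 1 to compound 3 (0.08 log units; within the scatter)), so the acylated nitrogen shows no measurable effect alongside cyano, and among the three compounds only compound 2, the one carrying ethoxycarbonyl, stands apart. Nothing available here gives a reason for the size of the step at this position.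

Still open, going by these compounds, is whether a carboxylic acid, a methyl ester or a primary amide on the same aromatic carbon would give a number close to that of compound 2 or to that of compound 3. Also open, on these data alone, is how ethoxycarbonyl behaves with a plain amino group in place of the ((cyanomethyl)carbonyl)amino group, which would show whether the low number needs both groups together.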